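Swapping Bromo for Chloro on a Benzamide Inhibitor

A few compounds are considered here, and "the series" means these few. Any claim that something is new, unique, unknown or untested is made for them only; others in the source may bear on it.

Measured so far in an assay for inhibition of Indoleamine 2,3-dioxygenase 1 (Homo sapiens), read by HPLC, with a stated time of 48 h; on this read-out higher numbers stand for weaker inhibition and lower numbers for stronger inhibition:
compound 1 `Cc1ccc2[nH]c(C(=O)NCc3cccc(Cn4cnc5ccccc54)c3)cc2c1` gives 636 nM
compound 2 `O=C(NCc1cccc(Cn2cnc3ccccc32)c1)c1nc2ccccc2[nH]1` gives 407 nM
compound 3 `O=C(NCc1cccc(Cn2cnc3ccccc32)c1)c1ccc(Br)cc1` gives 134 nM

Compound 3 has the lowest number of the three; the steps of a 4.7-fold lower number from compound 1 to compound 3 (0.68 log units; beyond the scatter) and a 3.0-fold lower number from compound 2 to compound 3 (0.48 log units; beyond the scatter) both lie beyond the scatter, so on these numbers it is the strongest inhibitor. Compound 4 `O=C(NCc1cccc(Cn2cnc3ccccc32)c1)c1ccc(Cl)cc1` keeps the core of compound 3 and differs only by chloro in place of bromo on an aromatic carbon. The measured steps each exchange the whole group on the carbonyl carbon, and none exchanges one halogen for another, so they bear only loosely on this change. With the step of a 1.6-fold lower number from compound 1 to compound 2 (0.19 log units; within the scatter) falling within the scatter for a larger swap, no step beyond the scatter is expected here, a 1.4-fold higher number from compound 3 to compound 4 (0.15 log units; within the scatter). Compound 4 is estimated at 190 nM, between 80 nM and 450 nM.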

Compound 4, half-maximal inhibitory concentration: 477 nM
For compound 4 the middle estimate is 2.5-fold (0.40 log units) below the measured one, outside the stated range (above it).
By their numbers in this assay, from the lowest: compound 3; then compounds 2, 4 and 1 (each within the scatter of the next).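

Exchanging one halogen for another at this place is not a silent change: a 3.6-fold higher number from compound 3 to compound 4 (0.55 log units; beyond the scatter) is a step beyond the scatter, although only one atom differs. With chloro, the group on the carbonyl carbon no longer stands apart from the other two, as a 1.2-fold higher number from compound 2 to compound 4 (0.07 log units; within the scatter) and a 1.3-fold lower number from compound 1 to compound 4 (0.12 log units; within the scatter) both lie within the scatter, so the low number of compound 3 goes with the bromo and not with any 4-halophenyl. Nothing available accounts for the gap between the two halogens. Still open, from the compounds shown here alone, is how fluoro, iodo, methyl or an amine at this place would compare with bromo. Going by these compounds, whether bromo keeps its edge over chloro on a different core also remains open.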